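Shortening the alkyl chain of compound 1 by one carbon

This account rests on a few compounds, and the source may have more. Where it says the series, first, only, none or still open, it means among the compounds named here.

Measured so far:
compound 1, `CCCCCCCN1CCC(C(=O)Nc2cc(Cl)c(N)cc2OC)CC1`: > 10 mg/kg
compound 2, `COc1cc(N)c(Cl)cc1NC(=O)C1CCN(Cc2ccc(F)cc2)CC1`: 0.6 mg/kg
compound 3, `COc1cc(N)c(Cl)cc1NC(=O)C1CCN(Cc2ccsc2)CC1`: 3.4 mg/kg

In a functional assay on the whole organism for antagonist activity, with Mus musculus as the target (a lower number here means that less compound is needed, a higher number that more compound is needed for the effect), compound 1 sits at a limit of the assay, (the limit of > 10 mg/kg in this assay, at which 1 of the 3 values shown sits), so only a boundary and no number is known for it. Compound 2 gives 0.6 mg/kg and compound 3 gives 3.4 mg/kg in this assay. Both measured steps leave the alkyl chain: an at least 16-fold lower number from compound 1 to compound 2 (1.22 log units; beyond the scatter) and an at least 2.9-fold lower number from compound 1 to compound 3 (0.46 log units; beyond the scatter). Compound 4, `CCCCCCN1CCC(C(=O)Nc2cc(Cl)c(N)cc2OC)CC1`, keeps the chain and only trims it: hydrogen in place of methyl on a saturated chain carbon, six bonds along the chain from an amine nitrogen in a ring. For the measured compounds named here, no measured step touches this change, and the two that replace the chain by a ring do not speak to one carbon less. Compound 4 is therefore expected to stay near compound 1, with a step that the limit leaves unreadable from compound 1 to compound 4, not beyond the scatter. Compound 4 is estimated at 15 mg/kg, between 6 mg/kg and 40 mg/kg, most likely reported again as a limit.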

Compound 4, dose for half-maximal effect: > 10 mg/kg
Compound 4: no number, only a limit; the forecaster's own chance of this, stated with the estimate: 65%; the middle value does not contradict the limit.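

In this assay compound 4 gives > 10 mg/kg, a limit of the assay and not a number, so the step from compound 1, itself held at a limit, cannot be read, and the two compounds share one boundary: the limit of > 10 mg/kg in this assay, at which 2 of the 4 values shown sit.

The trimmed chain still falls behind both ring groups at this position, with an at least 2.9-fold higher number from compound 3 to compound 4 (0.46 log units; beyond the scatter) and with an at least 16-fold higher number from compound 2 to compound 4 (1.22 log units; beyond the scatter).

Going by these compounds, whether a much shorter chain such as propyl, or a chain ending in an amine, would come off the limit remains open. So does how far past it compound 1 and compound 4 truly lie.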